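This account rests on a few compounds, and the source may have more. Where it says the series, first, only, none or still open, it means among the compounds named here.

Measured compounds:
compound 1 `N#Cc1ccc(Cn2nc(-c3cc(Cl)c(NCCO)nc3F)c3ccccc3c2=O)cc1` — 32100 nM
compound 2 `Cc1nc(-c2ccc(F)nc2F)cn(Cc2ccc(Cl)cc2)c1=O` — a limit, > 100000 nM

Both were tested in an ADME assay on HepG2 2.2.15 cells (Homo sapiens) for cytotoxicity, read by MTT assay, with a stated time of 8 days; on this read-out lower numbers stand for higher toxicity in this test and higher numbers for lower toxicity in this test. Compound 1 gives 32100 nM, the only plain number shown. For compound 2 the result is the limit of > 100000 nM in this assay, at which 1 of the 2 values shown sits, a limit rather than a number.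

Compound 3 `N#Cc1ccc(Cn2nc(-c3cc(Cl)c(NC[C@H](O)CO)nc3F)c3ccccc3c2=O)cc1` differs from compound 1 in one place: hydroxymethyl in place of hydrogen on a saturated chain carbon bound to an oxygen on a saturated carbon and a saturated chain carbon. Within the data shown here, no measured pair shows a change of this kind, so the size of the step is open. A small change is expected, a 1.2-fold higher number from compound 1 to compound 3 (0.10 log units; within the scatter), not clearly beyond the scatter, perhaps leaning toward lower toxicity. Compound 3 is therefore estimated at 40000 nM, within 15000 nM to 100000 nM.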

Compound 3, half-maximal cytotoxic concentration: > 100000 nM
Compound 3: only a limit was reported; the forecaster's own chance of this, stated with the estimate: 25%; at least 2.5-fold (0.39 log units) between middle value and limit.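

In this assay the change from (2-hydroxyethyl)amino to (2,3-dihydroxypropyl)amino gives an at least 3.1-fold higher number from compound 1 to compound 3 (0.49 log units; beyond the scatter) and so shows that this chain position responds to an added hydroxymethyl, toward lower toxicity in this test. The result for compound 3 is a limit and not a number, so the step has a lower bound but no known size: the limit of > 100000 nM in this assay, at which 2 of the 3 values shown sit.

As far as these compounds go, whether an amine or a carboxylic acid in place of the added hydroxymethyl would shift the read-out the same way stays open. From the compounds shown here alone, a longer chain at this position is equally open.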